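The source may report more compounds than this note shows. Statements on the series, on what has been measured and on what is new or still open speak of the compounds shown alone.

Measured compounds:
Compound 1, `Cc1ccccc1-c1nc(CN2CCC(C(=O)NCCCN3[C@H](C)CCC[C@@H]3C)CC2)c(C)o1`; in a physicochemical assay for solubility, in phosphate buffer, measured as kinetic solubility, at pH 7.4 (a lower number here means a less soluble compound, a higher number a more soluble compound), compound 1 gives > 69 ug/mL, a limit of the assay rather than a number.
Compound 2, `Cc1ccccc1-c1nc(CN2CCC(C(=O)NCCCCN3C[C@H](C)C[C@H](C)C3)CC2)c(C)o1`; in this assay compound 2 gives > 71 ug/mL, again a limit.
Compound 3, `Cc1cccc(F)c1-c1nc(CN2CCC(C(=O)NCCCN3C[C@H](C)C[C@H](C)C3)CC2)c(C)o1`; in this assay compound 3 gives > 72 ug/mL, also a limit.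

Compound 3 thus stands only at a limit, as do the two other values shown: the limit of > 69 ug/mL in this assay, at which 1 of the 3 values shown sits, (the limit of > 71 ug/mL in this assay, at which 1 of the 3 values shown sits), (the limit of > 72 ug/mL in this assay, at which 1 of the 3 values shown sits). Among the measured compounds shown here, the single measured step, a step that the two limits leave unreadable from compound 1 to compound 2, is the change of (3,5-dimethylpiperidin-1-yl)methyl in place of 2,6-dimethylpiperidin-1-yl on a saturated chain carbon, three bonds along the chain from an amide-type nitrogen; both ends sit at limits, so its size cannot be read.

Compound 4, `COc1cccc(OC)c1-c1nc(CN2CCC(C(=O)NCCCN3C[C@H](C)C[C@H](C)C3)CC2)c(C)o1`, differs from compound 3 by 2,6-dimethoxyphenyl in place of 2-fluoro-6-methylphenyl on an aromatic carbon. For the measured compounds named here, no measured step touches the aryl group on the shared core, so the change itself has no readable precedent here. What the three limits do show is that every measured member sits at the limit of this assay. Compound 4 is therefore expected to sit there as well, the expected step that the limit leaves unreadable from compound 3 to compound 4 being not readable beyond the scatter. The estimate for compound 4 is 80 ug/mL, with a range from 40 ug/mL to 160 ug/mL, most likely reported once more as a limit.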

Compound 4, solubility: > 76 ug/mL
Compound 4: only a limit was reported (the forecaster's own chance of this, stated with the estimate: 70%); the middle value does not contradict the limit.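

Compound 3 and compound 4 both stand at limits in this assay, and the step between them, 2,6-dimethoxyphenyl in place of 2-fluoro-6-methylphenyl, cannot be read. The compounds shown leave open where any of them actually lies in this assay, and whether any single change moves the read-out.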